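Chloro to methoxy on the 3-substituted benzyl group

This account rests on a few compounds, and the source may have more. Where it says the series, first, only, none or still open, it means among the compounds named here.

In a functional assay on BGC-823 cells (Homo sapiens) for antiproliferative activity, read by MTT assay, with a stated time of 24 h (a lower number here means a stronger inhibitor, a higher number a weaker inhibitor), compound 1 `c1ccc(CSc2nnc(-c3ccc4c(c3)OCCO4)n2-c2ccccc2)cc1` gives 73400 nM and compound 2 `Clc1ccccc1CSc1nnc(-c2ccc3c(c2)OCCO3)n1-c1ccccc1` gives 17400 nM while compound 3 `Clc1cccc(CSc2nnc(-c3ccc4c(c3)OCCO4)n2-c2ccccc2)c1` gives 51200 nM as its read-out. Compound 3 stands level with compound 1 within the scatter, as the step of a 1.4-fold lower number from compound 1 to compound 3 (0.16 log units; within the scatter) shows. It lies on the weaker side of compound 2, with a 2.9-fold higher number from compound 2 to compound 3 (0.47 log units; beyond the scatter) as the measured gap.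

Compound 4 `COc1cccc(CSc2nnc(-c3ccc4c(c3)OCCO4)n2-c2ccccc2)c1` differs from compound 3 by methoxy in place of chloro on an aromatic carbon in the form of methoxy in place of chloro on an aromatic carbon, meta to a large group. Among the compounds with values here, no methoxy compound has been measured yet. The nearest guide is the step of a 1.4-fold lower number from compound 1 to compound 3 (0.16 log units; within the scatter) at this same place, which is within the scatter. The larger step of a 4.2-fold lower number from compound 1 to compound 2 (0.63 log units; beyond the scatter) belongs to the 2-chlorophenyl group and bears on it less. No step beyond the scatter is therefore expected, and the estimated step is a 1.0-fold lower number from compound 3 to compound 4 (0.01 log units; within the scatter) in this assay for now.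

Compound 4 is expected at 50000 nM with an estimated range from 24000 nM to 105000 nM in this series.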

Compound 4, half-maximal inhibitory concentration: > 100000 nM
Compound 4 gave a limit, no number; the forecaster's own chance of this, stated with the estimate: 5%; at least 2.0-fold (0.30 log units) between middle value and limit.
By their numbers in this assay, from the lowest: compound 2; then compounds 3 and 1 (each within the scatter of the next). At a limit, above all of these: compound 4.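

In this assay compound 4 gives > 100000 nM, which is a limit of the assay and not a number. Methoxy in place of chloro at this position gives an at least 1.9-fold higher number from compound 3 to compound 4 (0.29 log units; that floor lies within the scatter), and methoxy in place of hydrogen gives an at least 1.3-fold higher number from compound 1 to compound 4 (0.13 log units; that floor lies within the scatter); both floors lie within the scatter, so neither step yet establishes a real change, though neither substituent at this position shows a gain over the plain benzyl group. The only gap here that clears the scatter is an at least 5.7-fold higher number from compound 2 to compound 4 (0.75 log units; beyond the scatter), which keeps the 2-chlorophenyl group ahead of the 3-methoxyphenyl group.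

From the compounds shown here alone, the true value behind the limit remains open, as does the effect of methoxy in place of the chloro of the 2-chlorophenyl group. Also open, going by these compounds, is whether an amine or a carboxylic acid on this aromatic carbon would give a readable value.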